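The source may hold more compounds than are shown below. What is called first, only, known or untested is meant among the compounds shown, and "the series" means these compounds.

Measured in an ADME assay on L6 cells (Rattus norvegicus) for cytotoxicity, read by resazurin assay, with a stated time of 72 h; on this read-out lower numbers stand for stronger inhibition and higher numbers for weaker inhibition:
Compound 1, `CSc1ccc(-c2noc(CN3N=N[C@@H]4C(=O)N(c5ccccc5)C(=O)[C@@H]43)n2)cc1`: compound 1 gives > 100 ug/mL
Compound 2, `O=C1[C@H]2N=NN(Cc3nc(-c4ccc(Br)cc4)no3)[C@H]2C(=O)N1c1ccccc1`: compound 2 gives 58.6 ug/mL
Compound 3, `Cc1ccc(-c2noc(CN3N=N[C@@H]4C(=O)N(c5ccccc5)C(=O)[C@@H]43)n2)cc1`: compound 3 gives 15.2 ug/mL

Compound 1 stands at the top of this small set, and its value is a limit of the assay rather than a number (the limit of > 100 ug/mL in this assay, at which 1 of the 3 values shown sits). The compound still to be measured is compound 4, `O=C1[C@H]2N=NN(Cc3nc(-c4ccc(I)cc4)no3)[C@H]2C(=O)N1c1ccccc1`. It differs from compound 1 in one place: iodo in place of methylsulfanyl on an aromatic carbon.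

Two measured steps start from the same compound 1 and replace the same group. With bromo in place of methylsulfanyl, the step was an at least 1.7-fold lower number from compound 1 to compound 2 (0.23 log units; that floor lies within the scatter). With methyl in place of methylsulfanyl, the step was an at least 6.5-fold lower number from compound 1 to compound 3 (0.81 log units; beyond the scatter). The third step, methyl in place of bromo, was a 3.9-fold lower number from compound 2 to compound 3 (0.59 log units; beyond the scatter). Every replacement of methylsulfanyl so far has pushed the number down, so for iodo in place of methylsulfanyl a lower number is expected in this assay, most likely of a size close to the bromo step. Compound 4 is therefore expected to give about 40 ug/mL, within a range from 15 ug/mL to 100 ug/mL. That estimate amounts to an expected at least 2.5-fold lower number from compound 1 to compound 4 (0.39 log units; beyond the scatter).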

Compound 4, half-maximal inhibitory concentration: 48.6 ug/mL
The estimate for compound 4 lay 1.2-fold (0.08 log units) below the measured number; the range from low to high includes it.
By their numbers in this assay, from the lowest: compound 3; then compounds 4 and 2 (each within the scatter of the next). At a limit, above all of these: compound 1.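

Iodo and bromo cannot be told apart at this position in this assay, with a 1.2-fold lower number from compound 2 to compound 4 (0.08 log units; within the scatter). Iodo in place of methyl gives a 3.2-fold higher number from compound 3 to compound 4 (0.50 log units; beyond the scatter), so the second halogen also stands clearly apart from methyl, as bromo did. Iodo in place of methylsulfanyl gives an at least 2.0-fold lower number from compound 1 to compound 4 (0.31 log units; beyond the scatter), and that size is only a floor, because compound 1 carries a limit and not a number: the limit of > 100 ug/mL in this assay, at which 1 of the 4 values shown sits.

From the compounds shown here alone, the true number for compound 1 remains unknown, so the full size of any step from it stays open. Going by these compounds, it is also open where a methoxy group, an amine or a carboxylic acid on the same aromatic carbon would fall relative to methyl and the two halogens.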